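A few compounds are considered here, and "the series" means these few. Any claim that something is new, unique, unknown or untested is made for them only; others in the source may bear on it.

The measured compounds and their values:

compound 1, `COc1ccc([C@H]2CC(C)(O)[C@@H]3CC[C@@H](C)C[C@H]3O2)cc1`, 689000 nM
compound 2, `COc1ccc([C@H]2CC(C)(O)[C@@H]3CC[C@@H](C)C[C@H]3O2)c(OC)c1`, > 937000 nM
compound 3, `COc1cc([C@H]2CC(C)(O)[C@@H]3CC[C@@H](C)C[C@H]3O2)ccc1O`, 411000 nM

Of the compounds shown here, three on a shared core have been tested in an ADME assay on MDCK cells (Canis lupus familiaris) for cytotoxicity, read by MTT assay, with a stated time of 48 h; a higher number here means that more compound is tolerated, a lower number that less compound is tolerated. Compound 1 gives 689000 nM. For compound 2 the assay reports only a limit, > 937000 nM, and the limit of > 937000 nM in this assay, at which 1 of the 3 values shown sits, is where that value sits. Compound 3 gives 411000 nM.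

Among the compounds with values here, the one change between measured compounds that is counted is methoxy in place of hydrogen on an aromatic carbon. It made an at least 1.3-fold higher number from compound 1 to compound 2 (0.13 log units; that floor lies within the scatter). The step from compound 1 to compound 2 is therefore bounded only from below, and its floor lies within the usual scatter. How the core of compound 1 and the core of compound 3 differ is not broken down here; their two values are within the scatter of each other.

Compound 4, `COc1cc([C@H]2CC(C)(O)[C@@H]3CC[C@@H](C)C[C@H]3O2)cc(OC)c1O`, has not been measured in this assay. It differs from compound 3 by methoxy in place of hydrogen on an aromatic carbon. Within the data shown here, this is the same kind of change as the one from compound 1 to compound 2, but the place is not the same: in compound 2 the entering methoxy sits ortho to a large group and meta to a methoxy group, whereas in compound 4 it sits ortho to a hydroxy group, meta to a large group and meta to a methoxy group.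

Since the step from compound 1 to compound 2 was an at least 1.3-fold higher number from compound 1 to compound 2 (0.13 log units; that floor lies within the scatter), the step from compound 3 to compound 4 is expected to be a 1.3-fold higher number from compound 3 to compound 4 (0.10 log units; within the scatter). Compound 4 is accordingly estimated at 520000 nM, within 220000 nM to 1000000 nM.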

Compound 4, half-maximal cytotoxic concentration: 473000 nM
The estimate for compound 4 lay 1.1-fold (0.04 log units) above the measured number; the measured number falls inside the stated range.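

In this assay, methoxy in place of hydrogen on an aromatic carbon gave a 1.2-fold higher number from compound 3 to compound 4 (0.06 log units; within the scatter), so on this core the change leaves the tolerated concentration within the usual scatter. Set beside the earlier step, the change can be compared across the two cores only this far: the same change on two cores in this assay, an at least 1.3-fold higher number (0.13 log units; that floor lies within the scatter) from compound 1 to compound 2 and a 1.2-fold higher number (0.06 log units; within the scatter) from compound 3 to compound 4; the limit leaves it open whether they differ. Compound 2 is recorded only as a limit, > 937000 nM, so the series does not show that the change carries from one core to another with the same size, nor that its size differs, and the place of the entering methoxy on the ring is not the same in the two steps.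

The compounds shown leave open how this assay would respond to a group other than methoxy on the aromatic ring, such as an amine or a carboxylic acid, or to a longer chain such as ethoxy or propoxy in its place. They also leave open what would happen if the hydroxy group of compound 3 and compound 4 were replaced, or if the change were made on the saturated part of the shared core rather than on an aromatic carbon.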